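The source may hold more compounds than are shown below. What is called first, only, known or untested is meant among the compounds shown, and "the series" means these compounds.

Compound 1 `Cc1cccc(-n2nncc2CN2C(=O)C3(C(C#N)=C(N)Oc4c3c3nc5ccccc5nc3c3ccccc43)c3ccccc32)c1` was examined in an ADME assay on L02 cells (Homo sapiens) for antiproliferative activity, read by MTT assay, with a stated time of 48 h; a lower number here means a stronger inhibitor, a higher number a weaker inhibitor. Compound 1 returns only a limit there, namely > 50000 nM. Two neighbours carry other groups on the same aromatic nitrogen of the shared core. Compound 2 `N#CC1=C(N)Oc2c(c3nc4ccccc4nc3c3ccccc23)C12C(=O)N(Cc1cnnn1-c1ccccc1Cl)c1ccccc12` also stops at the limit of this assay, with > 50000 nM. Compound 3 `N#CC1=C(N)Oc2c(c3nc4ccccc4nc3c3ccccc23)C12C(=O)N(Cc1cnnn1-c1ccc([N+](=O)[O-])cc1)c1ccccc12` likewise reaches only the limit, giving > 50000 nM. The steps between these three, a step that the two limits leave unreadable from compound 1 to compound 2, a step that the two limits leave unreadable from compound 1 to compound 3 and a step that the two limits leave unreadable from compound 2 to compound 3, cannot be sized because of the limit of > 50000 nM in this assay, at which 3 of the 3 values shown sit.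

Compound 4 `Cc1ccc(-n2nncc2CN2C(=O)C3(C(C#N)=C(N)Oc4c3c3nc5ccccc5nc3c3ccccc43)c3ccccc32)cc1Cl` has not yet been measured in this assay. It differs from compound 1 in one place: 3-chloro-4-methylphenyl in place of 3-methylphenyl on an aromatic nitrogen. The measured steps that bear on this change are the three just named, each a swap of the aryl group on that aromatic nitrogen, and none of them yields a readable size or direction. Among the compounds with values here, the only thing the measurements say, through (the limit of > 50000 nM in this assay, at which 3 of the 3 values shown sit), is that every such variation examined so far has remained at the limit.

Compound 4 is therefore expected to sit at that same limit, which corresponds to an estimated step that the limit leaves unreadable from compound 1 to compound 4. For compound 4 the estimated value in this assay is 70000 nM, within a range from 30000 nM to 250000 nM, and most probably only a limit will again be reported.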

Compound 4, half-maximal inhibitory concentration: > 50000 nM
Compound 4: a limit, no number (the forecaster's own chance of this, stated with the estimate: 85%); the middle value does not contradict the limit.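

The steps linking compound 4 with compound 1, compound 2 and compound 3 cannot be read, because each of these compounds returns only a limit: the limit of > 50000 nM in this assay, at which 4 of the 4 values shown sit. The compounds shown leave open whether any aryl group on that aromatic nitrogen would give a measurable value in this assay, and how large a step between such groups would be.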